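The source may hold more compounds than are shown below. What is called first, only, known or untested is meant among the compounds shown, and "the series" means these compounds.

Compound 1, `N[C@]1(C(=O)O)[C@H]2[C@@H](C[C@H]1OCc1cccc(Cl)c1)[C@]2(F)C(=O)O`: in an assay on CHO cells for binding affinity to metabotropic glutamate receptor 2 (Rattus norvegicus) (on this read-out higher numbers stand for weaker inhibition and lower numbers for stronger inhibition), compound 1 gives 3.28 nM.
Compound 2, `N[C@]1(C(=O)O)[C@H]2[C@@H](C[C@H]1OCc1ccc(-c3ccccc3)cc1)[C@]2(F)C(=O)O`: in this assay compound 2 gives 25.6 nM.

Compound 1 stands lowest of these two numbers; compound 2 sits higher, a gap beyond the usual scatter. Compound 3, `N[C@]1(C(=O)O)[C@H]2[C@@H](C[C@H]1OCc1cc(Cl)cc(Cl)c1)[C@]2(F)C(=O)O`, is not yet measured. It differs from compound 1 by chloro in place of hydrogen on an aromatic carbon. Among the measured compounds shown here, no measured pair in this set shows what such a change does, so the expectation rests on compound 1 alone. The expected step of a 1.2-fold lower number from compound 1 to compound 3 (0.07 log units; within the scatter) is no larger than the scatter, in no clear direction. Compound 3 is therefore estimated at 2.8 nM, with a range from 1 nM to 9 nM.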

Compound 3, inhibition constant: 5.61 nM
Beside the measured number, compound 3's estimate is 2.0-fold (0.30 log units) below it, within the range that was stated.
By their numbers in this assay, from the lowest: compounds 1 and 3 (each within the scatter of the next); then compound 2.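

Adding a second chloro group, which turns 3-chlorophenyl into 3,5-dichlorophenyl, gives in this assay a 1.7-fold higher number from compound 1 to compound 3 (0.23 log units; within the scatter), so the two compounds cannot be told apart on this read-out. This place on the aromatic ring can therefore carry a chloro group while binding stays in the same range as compound 1. Nothing available here explains this result.

As far as these compounds go, whether other groups fit at this place remains open. A methoxy group, a methyl group, an amine or a carboxylic acid could give quite a different number.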